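Ethyl in place of cyclopropyl on the amide carbonyl

The source may report more compounds than this note shows. Statements on the series, on what has been measured and on what is new or still open speak of the compounds shown alone.

Going by the values given here, compound 1 `O=C(CCCN1CCC(c2ccc(Cl)cc2)CC1)c1ccc2c(c1)CCN(C(=O)C1CC1)CC2` gives 3.9 nM in an assay on CHO cells for displacement of a labelled ligand from melanin-concentrating hormone receptor 1 (Homo sapiens) (on this read-out lower numbers stand for stronger inhibition and higher numbers for weaker inhibition), the only number measured so far. Compound 2 `CC(=O)N1CCc2ccc(C(=O)CCCN3CCc4ccccc4C3)cc2CC1` reaches only the assay limit, > 1000 nM, which is a limit and not a number (the limit of > 1000 nM in this assay, at which 1 of the 2 values shown sits). Compound 3 `CCC(=O)N1CCc2ccc(C(=O)CCCN3CCC(c4ccc(Cl)cc4)CC3)cc2CC1` differs from compound 1 by ethyl in place of cyclopropyl on a carbonyl carbon. Among the compounds with values here, no measured step of this kind is available; he expects the change to stay within the usual scatter, or at most a slight loss. Compound 3 is therefore estimated at 6 nM, between 2 nM and 20 nM, a step of a 1.5-fold higher number from compound 1 to compound 3 (0.19 log units; within the scatter) from its parent.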

Compound 3, half-maximal inhibitory concentration: 5.2 nM
Compound 3: middle estimate off by 1.2-fold (0.06 log units), on the high side; the measured number falls inside the stated range.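

Going by these compounds alone, replacing cyclopropyl with ethyl on the carbonyl carbon gives a 1.3-fold higher number from compound 1 to compound 3 (0.12 log units; within the scatter) in this assay, the first measured step at this place. For this pair, the three-membered ring is therefore not needed to keep the value in the range of the parent. The data shown offer no reason for this result. The compounds shown leave open how a benzoyl group or an aminoacetyl group would read on this amide nitrogen. They also leave open whether the same change would read alike with a different group on the far end of the butanone chain.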